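A few compounds are considered here, and "the series" means these few. Any claim that something is new, unique, unknown or untested is made for them only; others in the source may bear on it.

Measured so far:
compound 1, `CC(C)CC(=O)Oc1ccc2oc(/C=C/[S+](C)[O-])cc(=O)c2c1` — 2300 nM
compound 2, `Cc1cccc2c(=O)cc(/C=C/[S+](C)[O-])oc12` — 1700 nM
compound 3, `Cc1c(/C=C/[S+](C)[O-])oc2ccccc2c1=O` — 1500 nM

These three numbers come from a functional assay on A549 cells (Homo sapiens) for cytotoxicity, with a stated time of 48 h; on this read-out higher numbers stand for weaker inhibition and lower numbers for stronger inhibition. Compound 1 gives the highest of the three, but compound 2 and compound 3 both lie within the usual scatter of it, so on this assay the three cannot be told apart. Compound 4, `CC(C)C(=O)Oc1ccc2oc(/C=C/[S+](C)[O-])cc(=O)c2c1`, has not yet been tested. It differs from compound 1 in one place: isopropyl in place of isobutyl on a carbonyl carbon. The ester is kept and only the chain on its carbonyl carbon is shortened. Going by the values given here, no measured pair shows the effect of such a change, and a shift of one carbon in this position is expected to leave the number unchanged beyond the scatter. The step of no change at the digits printed from compound 1 to compound 4 (within the scatter) is the estimated outcome, so compound 4 is expected to give about 2300 nM, most likely between 1100 nM and 4800 nM.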

Compound 4, half-maximal inhibitory concentration: 2400 nM
Beside the measured number, compound 4's estimate is 1.0-fold (0.02 log units) below it; measured number inside the range.
By their numbers in this assay, from the lowest: compounds 3, 2, 1 and 4 (each within the scatter of the next).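

In this assay, isopropyl in place of isobutyl on the carbonyl carbon gives a 1.0-fold higher number from compound 1 to compound 4 (0.02 log units; within the scatter) and so leaves the number unchanged within the scatter. Going by these compounds alone, this is the first pair here that differs in one place, and it shows that this one-carbon change to the ester chain has no detectable effect. No supporting measurement bears on this result.

Only these two branched chains can be compared at this position. Going by these compounds, whether a longer chain such as hexyl, a phenyl ring or an amine on this carbonyl carbon would shift the number stays open.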